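Swapping the methoxyphenyl of compound 1 for a pyridyl ring

The source may report more compounds than this note shows. Statements on the series, on what has been measured and on what is new or still open speak of the compounds shown alone.

Measured in an assay on S100 cells for inhibition of Polyunsaturated fatty acid 5-lipoxygenase (Homo sapiens), read by HPLC, with stated times of 15 min and 10 min; a higher number here means a weaker inhibitor, a lower number a stronger inhibitor:
- compound 1, `COc1cccc(-c2nc3ccc(C)cn3c2NC2CCCCC2)c1`, gives 430 nM
- compound 2, `Oc1ccc(-c2nc3ccc(Br)cn3c2NC2CCCCC2)cc1`, gives 900 nM

Compound 1 stands lowest of the two numbers, and the nearest, compound 2, sits beyond the usual scatter above it. Compound 3, `Cc1ccc2nc(-c3ccncc3)c(NC3CCCCC3)n2c1`, is not yet measured. It differs from compound 1 in one place: pyridin-4-yl in place of 3-methoxyphenyl on an aromatic carbon. Within the data shown here, no measured pair shows this kind of change, so the expected size of the step rests on judgement alone. A modest weakening in this assay seems the likelier outcome, and the expected step is estimated at a 2.3-fold higher number from compound 1 to compound 3 (0.37 log units; beyond the scatter). For compound 3 the estimate is therefore 1000 nM, within a range from 300 nM to 3500 nM.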

Compound 3, half-maximal inhibitory concentration: 7700 nM
Compound 3: the middle estimate sits 7.7-fold (0.89 log units) below what was measured; measured number above the stated range.
By their numbers in this assay, from the lowest: compound 1; then compound 2; then compound 3.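

In this assay, the group on this aromatic carbon matters a great deal: pyridin-4-yl in place of 3-methoxyphenyl gives an 18-fold higher number from compound 1 to compound 3 (1.25 log units; beyond the scatter), a large loss of inhibition. This is the only step shown that isolates a change at this position, with the methyl and cyclohexylamino groups held fixed. Nothing available here explains the size of this loss.

The compounds shown leave open whether the loss goes with the ring nitrogen or with the missing methoxy group, since both change together. A plain phenyl ring at this place would help separate the two.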